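Trading 3-methylphenyl for 4-(tert-butyl)phenyl

A few compounds are considered here, and "the series" means these few. Any claim that something is new, unique, unknown or untested is made for them only; others in the source may bear on it.

Compound 1 `COc1cccc(CNc2nc(Nc3ccc(N4CCN(C)CC4)cn3)ncc2Cl)c1` gives 19500 nM
Compound 2 `CN1CCN(c2ccc(Nc3ncc(Cl)c(NCc4ccco4)n3)nc2)CC1` gives 21300 nM
Compound 3 `Cc1cccc(Nc2nc(Nc3ccc(N4CCN(C)CC4)cn3)ncc2Cl)c1` gives 7160 nM

These values come from a functional assay on MCF7 cells (Homo sapiens) for inhibition, read by CCK-8 assay, with a stated time of 48 h (on this read-out higher numbers stand for weaker inhibition of growth and lower numbers for stronger inhibition of growth), and compound 3 has the lowest number of the three. Compound 4 `CN1CCN(c2ccc(Nc3ncc(Cl)c(Nc4ccc(C(C)(C)C)cc4)n3)nc2)CC1` carries 4-(tert-butyl)phenyl in place of 3-methylphenyl on a nitrogen on an aromatic ring. The nearest evidence is a 2.7-fold lower number from compound 1 to compound 3 (0.44 log units; beyond the scatter) and a 3.0-fold lower number from compound 2 to compound 3 (0.47 log units; beyond the scatter) on replacing 3-methoxybenzyl or (furan-2-yl)methyl with 3-methylphenyl. Neither modest step compares two groups of the kind exchanged here, so neither gives a direction. In this assay the expected step, with no shift beyond the scatter foreseen, is a 1.1-fold lower number from compound 3 to compound 4 (0.04 log units; within the scatter) as an estimate. For compound 4 the estimated value is 6500 nM with an expected range from 2500 nM to 18000 nM in this read-out.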

Compound 4, concentration for 50% growth inhibition: 12600 nM
For compound 4 the middle estimate is 1.9-fold (0.29 log units) below the measured one; the measured number falls inside the stated range.
By their numbers in this assay, from the lowest: compounds 3, 4, 1 and 2 (each within the scatter of the next, the first and the last beyond it).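

On this nitrogen, this assay shows a 1.8-fold higher number from compound 3 to compound 4 (0.25 log units; within the scatter) so the larger 4-(tert-butyl)phenyl group leaves the number essentially where 3-methylphenyl put it. The comparisons with the other two groups give a 1.7-fold lower number from compound 2 to compound 4 (0.23 log units; within the scatter) and a 1.5-fold lower number from compound 1 to compound 4 (0.19 log units; within the scatter) so, unlike compound 3, compound 4 does not separate from the compounds carrying (furan-2-yl)methyl or 3-methoxybenzyl. Nothing available here gives a measured reason for these results. Still open, on these data alone, is whether a phenyl ring carrying an amine or a carboxylic acid at this place would move the number beyond the scatter.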